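The source may report more compounds than this note shows. Statements on the series, on what has been measured and on what is new or still open speak of the compounds shown alone.

Working notes on the series.

Compound 1 `CN(Cc1ccc(OCCCN)cc1)c1nc2ccc(Oc3ccccc3)cc2s1` and compound 2 `CN(Cc1ccc(OCCCN)cc1)c1nc2ccc(Oc3ccc(C(F)(F)F)cc3)cc2s1` share one core and differ only at the phenoxy end. In an assay on SH-SY5Y cells for inhibition of Voltage-dependent N-type calcium channel subunit alpha-1B (Homo sapiens), read by FLIPR and calcium flux, with stated times of 600 s and 300 s, in the presence of a further agent that is not named here (a higher number here means a weaker inhibitor, a lower number a stronger inhibitor), compound 1 gives 49000 nM, and compound 2 gives 283000 nM. The change between them, (hydrogen in place of trifluoromethyl on an aromatic carbon), produced a 5.8-fold lower number from compound 2 to compound 1 (0.76 log units; beyond the scatter).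

Compound 3 `NCCCOc1ccc(CNc2nc3ccc(Oc4cccc(C(F)(F)F)c4)cc3s2)cc1` carries a different core; the difference between its core and that of compound 2 is not broken down here. In this assay compound 3 gives 144000 nM, a number that sits within the scatter of compound 2 and beyond the scatter relative to compound 1.

Compound 4 `NCCCOc1ccc(CNc2nc3ccc(Oc4ccccc4)cc3s2)cc1` has not yet been measured in this assay. It stands to compound 3 as compound 1 stands to compound 2: the change is hydrogen in place of trifluoromethyl on an aromatic carbon. The two changes are the same kind of change, not the same, since in the pair of compound 2 and compound 1 the trifluoromethyl sits para to a large group, while in the pair of compound 3 and compound 4 it sits meta to a large group.

Expectation: the step from compound 3 to compound 4 in this assay is estimated as a 4.1-fold lower number from compound 3 to compound 4 (0.61 log units; beyond the scatter), resting on the step of a 5.8-fold lower number from compound 2 to compound 1 (0.76 log units; beyond the scatter) seen with the same kind of change on the other core, with a somewhat smaller size taken. The ring position and the core differ between the two pairs, and what that difference is worth has not been measured here. On that basis compound 4 is expected to give about 35000 nM in this assay, with a plausible span from 12000 nM to 100000 nM.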

Compound 4, half-maximal inhibitory concentration: 218000 nM
Beside the measured number, compound 4's estimate is 6.2-fold (0.79 log units) below it; measured number outside the range, above it.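

In this assay, putting hydrogen in place of trifluoromethyl on the core of compound 3 gives a 1.5-fold higher number from compound 3 to compound 4 (0.18 log units; within the scatter), a step that stays within the usual scatter, while putting hydrogen in place of methyl on the nitrogen, with the phenoxy end unchanged, gives a 4.4-fold higher number from compound 1 to compound 4 (0.65 log units; beyond the scatter). The trifluoromethyl step therefore does not carry over in size from the core of compound 2 to the core of compound 3, and the two steps differ: the same change on two cores in this assay, a 5.8-fold lower number (0.76 log units; beyond the scatter) from compound 2 to compound 1 and a 1.5-fold higher number (0.18 log units; within the scatter) from compound 3 to compound 4, 8.7-fold (0.94 log units) apart, beyond the scatter of two such steps. This does not show that the core alone sets the size of the step, since the two pairs also differ in where the trifluoromethyl sits on the ring, and a single pair on each core cannot separate the two influences.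

On these data alone, it remains open how the 3-(trifluoromethyl)phenoxy group would read on the core of compound 1, which would compare the two cores with the group in the same place. Also open, as far as these compounds go, is how a nitrile or a chlorine in place of trifluoromethyl, or a longer chain carrying the terminal amine, would read in this assay.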